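Trimming the Ester from a Urea Side Chain

A few compounds are considered here, and "the series" means these few. Any claim that something is new, unique, unknown or untested is made for them only; others in the source may bear on it.

Of the compounds shown here, three sharing one core have been tested in a functional assay on CCRF-CEM cells (Homo sapiens); a lower number here means that less compound is tolerated, a higher number that more compound is tolerated. Compound 1 `Cc1cn([C@@H]2O[C@H](CO[Si](C)(C)C(C)(C)C)[C@@]3(OS(=O)(=O)C=C3NCC(N)=O)[C@H]2O[Si](C)(C)C(C)(C)C)c(=O)n(C)c1=O` gives 14600 nM in this assay. Compound 2 `CCOC(=O)CNC(=O)NC1=CS(=O)(=O)O[C@@]12[C@@H](CO[Si](C)(C)C(C)(C)C)O[C@@H](n1cc(C)c(=O)n(C)c1=O)[C@@H]2O[Si](C)(C)C(C)(C)C` gives 5020 nM, the lowest of the two numbers, with the nearest being compound 1 at a step of a 2.9-fold lower number from compound 1 to compound 2 (0.46 log units; beyond the scatter). Compound 3 `Cc1cn([C@@H]2O[C@H](CO[Si](C)(C)C(C)(C)C)[C@@]3(OS(=O)(=O)C=C3NCCC(=O)OCc3ccccc3)[C@H]2O[Si](C)(C)C(C)(C)C)c(=O)n(C)c1=O` reaches only a limit of the assay, > 250000 nM, so no number is known for it (the limit of > 250000 nM in this assay, at which 1 of the 3 values shown sits).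

Compound 4 `CCNC(=O)NC1=CS(=O)(=O)O[C@@]12[C@@H](CO[Si](C)(C)C(C)(C)C)O[C@@H](n1cc(C)c(=O)n(C)c1=O)[C@@H]2O[Si](C)(C)C(C)(C)C` has not been measured. It differs from compound 2 by methyl in place of ethoxycarbonyl on a saturated chain carbon bound to an amide-type nitrogen.

The steps toward compound 3 are the largest: an at least 17-fold higher number from compound 1 to compound 3 (1.23 log units; beyond the scatter) and an at least 49-fold higher number from compound 2 to compound 3 (1.69 log units; beyond the scatter), but both introduce a benzyloxycarbonyl group rather than remove an ester, so they speak to the change only indirectly. The step of a 2.9-fold lower number from compound 1 to compound 2 (0.46 log units; beyond the scatter) is the modest one in which the ester was added, and the present change takes it away again. The expected outcome is therefore a modest rise, a 2.0-fold higher number from compound 2 to compound 4 (0.30 log units; within the scatter), with compound 4 estimated at 10000 nM in this assay, within a range of 3000 nM to 40000 nM.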

Compound 4, half-maximal cytotoxic concentration: 4260 nM
Estimate against measurement, compound 4: 2.3-fold (0.37 log units) above; measured number inside the range.
By their numbers in this assay, from the lowest: compounds 4 and 2 (each within the scatter of the next); then compound 1. At a limit, above all of these: compound 3.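

In this assay compound 2 and compound 4 cannot be told apart (a 1.2-fold lower number from compound 2 to compound 4 (0.07 log units; within the scatter)), so at this saturated chain carbon bound to an amide-type nitrogen, ethoxycarbonyl and methyl read the same, and the ester is not required for the number seen with compound 2. The gap to compound 1 also holds without the ester (a 3.4-fold lower number from compound 1 to compound 4 (0.53 log units; beyond the scatter)), which shows that the ethylcarbamoyl group on the amine nitrogen gives a lower number than carbamoylmethyl even when it carries no ester at all. Compound 3, with 2-(benzyloxycarbonyl)ethyl on that nitrogen, gives a limit of the assay and not a number, so its step is large but only a bound (an at least 58-fold lower number from compound 3 to compound 4 (1.76 log units; beyond the scatter)): the limit of > 250000 nM in this assay, at which 1 of the 4 values shown sits.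

The compounds shown leave open how a carboxylic acid or an amine at the end of this chain would read, and whether a longer chain such as butyl would stay level with ethyl. They also leave open whether a ring such as phenyl in place of the ethyl group would keep the number or move it toward that of compound 3.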